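Replacing isopropoxy with bromo on a phenoxy-imidazoline core

The source may hold more compounds than are shown below. What is called first, only, known or untested is meant among the compounds shown, and "the series" means these compounds.

Measured compounds:
Compound 1 `CC(Oc1ccccc1C=O)C1=NCCN1` gives 2090 nM in an assay on CHO cells for displacement of a labelled ligand from Alpha-2B adrenergic receptor (Homo sapiens); on this read-out lower numbers stand for stronger inhibition and higher numbers for weaker inhibition.
Compound 2 `CC(C)Oc1ccccc1OC(C)C1=NCCN1` gives 1580 nM in this assay.
Compound 3 `Cc1cccc(C)c1OC(C)C1=NCCN1` gives 182 nM in this assay.

Compound 2 stands second highest of the three numbers: compound 1 is its nearest neighbour and compound 3 is furthest away, with a number far lower than either. The unmeasured compound 4 `CC(Oc1ccccc1Br)C1=NCCN1` differs from compound 2 in one place: bromo in place of isopropoxy on an aromatic carbon.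

For the measured compounds named here, only one measured step changes the same position: a 1.3-fold lower number from compound 1 to compound 2 (0.12 log units; within the scatter), a change that stayed within the scatter. It does not involve bromo, so it gives no direct guide. Going by the values given here, compound 3 shows that a smaller group at that position can go with a much lower number than compound 2, though compound 3 differs from compound 2 in more than one place and no single step connects them. Compound 4 is therefore expected to give a lower number, a 4.0-fold lower number from compound 2 to compound 4 (0.60 log units; beyond the scatter), with wide uncertainty. The estimate for compound 4 in this assay is 400 nM, ranging from 100 nM to 1600 nM.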

Compound 4, inhibition constant: 355 nM
For compound 4 the middle estimate is 1.1-fold (0.05 log units) above the measured one; the measured number falls inside the stated range.
By their numbers in this assay, from the lowest: compounds 3 and 4 (each within the scatter of the next); then compounds 2 and 1 (each within the scatter of the next).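

In this assay the change from isopropoxy to bromo gives a 4.5-fold lower number from compound 2 to compound 4 (0.65 log units; beyond the scatter) and so shows that this aromatic carbon does respond to the group placed on it, something the earlier step from formyl to isopropoxy (a 1.3-fold lower number from compound 1 to compound 2 (0.12 log units; within the scatter)) could not show. Bromo in place of formyl gives a 5.9-fold lower number from compound 1 to compound 4 (0.77 log units; beyond the scatter) as well, so bromo stands apart from two different starting groups, while those two groups remain within the scatter of each other. Nothing shown here explains why the number falls.

The compounds shown leave open whether other groups at this carbon, such as chloro, an amine or a longer chain, would give numbers like that of compound 4 or like that of compound 2. They also leave open whether the same change would give a step of similar size on a core carrying other groups.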